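A few compounds are considered here, and "the series" means these few. Any claim that something is new, unique, unknown or untested is made for them only; others in the source may bear on it.

Compound 3 `CCC1(Cc2ccccc2)OS(=O)(=O)C=C1OCc1ccc(C(F)(F)F)cc1` is the only one of the three measured compounds for which an ADME assay on HEL cells (Homo sapiens) for cytotoxicity, with a stated time of 3 days (on this read-out lower numbers stand for higher toxicity in this test and higher numbers for lower toxicity in this test), reports a plain number, namely 99000 nM. Compound 1 `CCC1(Cc2ccccc2)OS(=O)(=O)C=C1OCc1ccc([N+](=O)[O-])cc1` shows in this assay only a limit, < 200000 nM. Compound 2 `C=CCOC1=CS(=O)(=O)OC1(CC)Cc1ccccc1` likewise shows in this assay only a limit, > 200000 nM. Both measured steps thus remain without a readable size, a number no lower from compound 1 to compound 2 (the limit leaves the size open) and a step that the limit leaves unreadable from compound 1 to compound 3, because the limit of < 200000 nM in this assay, at which 1 of the 3 values shown sits, and the limit of > 200000 nM in this assay, at which 1 of the 3 values shown sits, mark the edges of what this assay can report.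

Compound 4 `CCC1(Cc2ccccc2)OS(=O)(=O)C=C1OCc1ccc(C)cc1` differs from compound 3 by methyl in place of trifluoromethyl on an aromatic carbon. For the measured compounds named here, no measured step covers this exchange, and the two steps that exist cannot be read for size, so nothing in the data points to a shift beyond the usual scatter in this assay. The expected step is accordingly a 1.1-fold higher number from compound 3 to compound 4 (0.05 log units; within the scatter), a change that stays within that scatter. Compound 4 is estimated to give 110000 nM in this assay, with a likely range from 40000 nM to 250000 nM, and a fair chance that only a limit is reported.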

Compound 4, half-maximal cytotoxic concentration: 41500 nM
Compound 4: the middle estimate sits 2.7-fold (0.42 log units) above what was measured, within the range that was stated.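

For the compounds shown here, on the aromatic carbon para to a large group, methyl in place of trifluoromethyl gives the only step at this position with a readable size: in this assay there is a 2.4-fold lower number from compound 3 to compound 4 (0.38 log units; beyond the scatter). The group on this carbon can therefore move the read-out beyond the usual scatter, towards higher toxicity in this test for the methyl compound. A larger exchange, 4-methylphenyl in place of vinyl, gives an at least 4.8-fold lower number from compound 2 to compound 4 (0.68 log units; beyond the scatter), a size that rests on a limit, not a number, for compound 2.

From the compounds shown here alone, the step from compound 1 to compound 4 cannot be read because one of its two values is only a limit: the limit of < 200000 nM in this assay, at which 1 of the 4 values shown sits. Whether an amine or a carboxylic acid on this same aromatic carbon would lower the number further, or raise it, stays open.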